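Swapping the side chain of compound 2

The source may hold more compounds than are shown below. What is called first, only, known or untested is meant among the compounds shown, and "the series" means these compounds.

In a functional assay on HCT-116 cells (Homo sapiens) for inhibition, read by sulforhodamine B assay, with a stated time of 48 h (on this read-out higher numbers stand for weaker inhibition and lower numbers for stronger inhibition), compound 2 `COc1ccc(C(c2ccc(OC(C)CN(C)C)cc2)c2cccc3ccccc23)c(OC)c1OC` gives 8410 nM. Compound 1 `CCOC(=O)CCO/N=C(/c1ccc(OC)c(OC)c1OC)c1cccc2ccccc12` gives 10000 nM, and these two values lie within the usual scatter of each other. Compound 3 `C=CCC(O)(c1ccc(OC)c(OC)c1OC)c1cccc2ccccc12` gives only a limit of the assay, > 20000 nM. Compound 4 `COc1ccc(C(c2ccc(OCCO)cc2)c2cccc3ccccc23)c(OC)c1OC` differs from compound 2 in one place: 2-hydroxyethyl in place of 1-((dimethylamino)methyl)ethyl on an oxygen on an aromatic ring. It carries 2-hydroxyethyl in place of 1-((dimethylamino)methyl)ethyl on an oxygen on an aromatic ring. Among the compounds with values here, no measured pair here shows this change, so the expectation stays cautious. The expected step of a 1.3-fold higher number from compound 2 to compound 4 (0.12 log units; within the scatter) leans slightly towards weaker inhibition in this assay but stays within the scatter. For compound 4 the estimated value is 11000 nM, with an expected range of 4500 nM to 20000 nM.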

Compound 4, half-maximal inhibitory concentration: > 20000 nM
Compound 4 was reported as a limit; the forecaster's own chance of this, stated with the estimate: 30%; at least 1.8-fold (0.25 log units) between middle value and limit.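

In this assay, within the data shown here, this is the first direct evidence that the group on this oxygen affects the read-out: 2-hydroxyethyl in place of 1-((dimethylamino)methyl)ethyl gives an at least 2.3-fold higher number from compound 2 to compound 4 (0.37 log units; beyond the scatter). The value for compound 4 is a limit, so the real size of this step remains unknown: the limit of > 20000 nM in this assay, at which 2 of the 4 values shown sit.

The change replaces both the chain and its end group, and the compounds shown do not separate these two parts. Going by these compounds, whether 2-(dimethylamino)ethyl or a carboxylic acid on this oxygen would match compound 2 remains open.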